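A few compounds are considered here, and "the series" means these few. Any claim that something is new, unique, unknown or untested is made for them only; others in the source may bear on it.

Three members of the series have numbers in a functional assay on NCI-H23 cells (Homo sapiens) for inhibition, read by sulforhodamine B assay, with a stated time of 48 h, tested at 10 uM; a lower number here means less inhibition, a higher number more inhibition at the concentration tested (going by the name of the read-out). Compound 1 `c1ccc2c(-c3cn4ccnc4c(-c4ccc5ncn(C6CCCCC6)c5c4)n3)cccc2c1` gives 4.32%; compound 2 `Brc1ccc(-c2cn3ccnc3c(-c3ccc4ncn(C5CCCCC5)c4c3)n2)cc1` gives 8.38%; compound 3 `c1cn2cc(-c3ccc4c(c3)ncn4C3CCCCC3)nc(-c3ccc4ncn(C5CCCCC5)c4c3)c2n1` gives 20.5%. Among the compounds with values here, the only step between measured compounds that differ in one place, a number 4.1 percentage points higher from compound 1 to compound 2 (within the scatter), lies within the scatter. Compound 3 stands highest of the three numbers, beyond the scatter from both compound 2 and compound 1.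

Compound 4 `c1ccc(Cn2cnc3ccc(-c4nc(-c5ccc6c(c5)ncn6C5CCCCC5)cn5ccnc45)cc32)cc1` is not yet measured. Against compound 3 it differs in one place: benzyl in place of cyclohexyl on an aromatic nitrogen. Within the data shown here, no measured step touches the substituent on the aromatic nitrogen; the one step available concerns an aromatic carbon and is of no use here, so nothing points to a direction. The expectation for the step of a number 0.5 percentage points lower from compound 3 to compound 4 (within the scatter) is therefore one of no change beyond the scatter. Compound 4 is expected to give about 20% in this assay, with a range from 5% to 38% reflecting the wide uncertainty.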

Compound 4, a percentage reported as inhibition, at one concentration (the size of the read-out at that concentration, not a potency): -22.8%
Estimate against measurement, compound 4: 42.8 percentage points above; the whole stated range lies above it.
By their numbers in this assay, from the lowest: compound 4; then compounds 1 and 2 (each within the scatter of the next); then compound 3.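

Within the data shown here, the substituent on the aromatic nitrogen is far from silent in this assay: benzyl in place of cyclohexyl brings a number 43.3 percentage points lower from compound 3 to compound 4 (beyond the scatter) and is the first single change to go beyond the scatter, the earlier step on an aromatic carbon having stayed within it. A six-membered non-aromatic ring gives way here to a six-membered aromatic ring on a carbon link, and compound 4 at -22.8% falls on the negative side of the read-out, unlike the three earlier compounds. Nothing available bears on why the number moves this far.

Going by these compounds, it remains open whether the loss follows the aromatic ring or the carbon link, which cyclohexylmethyl or phenyl on the same nitrogen could separate. On these data alone, how a morpholine or a longer alkyl chain at this position would read also remains open.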